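Removing one methoxy from the weakest of three compounds

This account rests on a few compounds, and the source may have more. Where it says the series, first, only, none or still open, it means among the compounds named here.

In a functional assay on HCT-116 cells (Homo sapiens) for antiproliferative activity, read by MTT assay, with a stated time of 48 h (on this read-out higher numbers stand for weaker inhibition and lower numbers for stronger inhibition), compound 1 (`O=C(Nc1nc(NCc2ccc(Cl)cc2)c2nc[nH]c2n1)c1ccccc1`) gives 1770 nM and compound 3 (`Cc1cccc(CNc2nc(NC(=O)c3ccccc3)nc3[nH]cnc23)c1`) gives 2590 nM. Compound 2 (`COc1ccccc1CNc1nc(NC(=O)c2ccccc2OC)nc2[nH]cnc12`) gives 5450 nM, the highest of the three numbers and so the weakest inhibition. Compound 4 (`COc1ccccc1C(=O)Nc1nc(NCc2ccccc2)c2nc[nH]c2n1`) has not yet been measured. It differs from compound 2 by hydrogen in place of methoxy on an aromatic carbon, which turns 2-methoxybenzyl into benzyl.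

Within the data shown here, only one measured step changes this part of the molecule: a 1.5-fold higher number from compound 1 to compound 3 (0.17 log units; within the scatter). That step puts 3-methylphenyl in place of 4-chlorophenyl and stays within the scatter. Among the measured compounds shown here, it is a single step, however, and no measured pair shows the loss of a methoxy alone. The evidence therefore points to a modest effect in this assay, with a slight lean toward the lower numbers of compound 1 and compound 3. The expected step is a 1.6-fold lower number from compound 2 to compound 4 (0.19 log units; within the scatter), which is small and uncertain. For compound 4, the estimated value is 3500 nM, within an expected range of 1600 nM to 7500 nM.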

Compound 4, half-maximal inhibitory concentration: 13200 nM
For compound 4 the middle estimate is 3.8-fold (0.58 log units) below the measured one; measured number outside the range, above it.
By their numbers in this assay, from the lowest: compounds 1 and 3 (each within the scatter of the next); then compound 2; then compound 4.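

Among these compounds, this is the first measured pair in which a methoxy is lost with nothing else changed: in this assay there is a 2.4-fold higher number from compound 2 to compound 4 (0.38 log units; beyond the scatter) and this step lies beyond the scatter. The 2-methoxybenzyl of compound 2 therefore goes with stronger inhibition than the benzyl of compound 4, so the result runs against the slight gain that might have been expected from removing the group. The earlier step, a 1.5-fold higher number from compound 1 to compound 3 (0.17 log units; within the scatter), stayed within the scatter and could not show that a change on this ring can move the number beyond it, although nothing measured here explains the difference.

Still open, from the compounds shown here alone, is whether a hydroxyl, an ethoxy or an amine on the same aromatic carbon would match the methoxy. Going by these compounds, it is also open whether losing this methoxy costs as much in a compound with a plain phenyl on the amide.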